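Swapping a methoxy benzyl for an ethyl benzyl

A few compounds are considered here, and "the series" means these few. Any claim that something is new, unique, unknown or untested is made for them only; others in the source may bear on it.

Compound 1 `CCc1ccccc1CNC(=O)c1nc2ccc(F)c(OCCc3ccc(C(=O)O)cc3)c2c(=O)[nH]1`: > 20000 nM (a limit)
Compound 2 `CCc1cccc(CN(C)C(=O)c2nc3ccc(F)c(OCCc4ccc(C(=O)O)cc4)c3c(=O)[nH]2)c1`: > 20000 nM (a limit)
Compound 3 `COc1cccc(CNC(=O)c2nc3cccc(COCc4ccc(C(=O)O)cc4)c3c(=O)[nH]2)c1`: > 20000 nM (a limit)

These values come from an ADME assay on HEK293 cells (Homo sapiens) for cytotoxicity, read by resazurin assay, with a stated time of 72 h; a lower number here means that less compound is tolerated, a higher number that more compound is tolerated. Compound 3 gives > 20000 nM, which is a limit and not a number. It shares this position with the other two compounds, as the record shows (the limit of > 20000 nM in this assay, at which 3 of the 3 values shown sit). No measured value therefore fixes how much of compound 3 the cells tolerate.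

The next compound, compound 4 `CCc1ccc(CNC(=O)c2nc3cccc(COCc4ccc(C(=O)O)cc4)c3c(=O)[nH]2)cc1`, keeps the core of compound 3 and changes one group: 4-ethylphenyl in place of 3-methoxyphenyl on a saturated chain carbon bound to an amide-type nitrogen. In words, 4-ethylphenyl stands in place of 3-methoxyphenyl on a saturated chain carbon bound to an amide-type nitrogen.

Going by the values given here, only one measured step bears on this change, and it was made on the core of compound 1, where an ethyl-carrying benzyl group is also present: a step that the two limits leave unreadable from compound 1 to compound 2. That step gives no size to carry over. Compound 2 gives > 20000 nM, also a limit, so an ethyl-carrying benzyl group appears there without any measured drop in this assay.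

No step beyond the usual scatter is expected, in either direction, and the expected change is a step that the limit leaves unreadable from compound 3 to compound 4. The assay will most likely report only a limit again. For compound 4 the estimated value is 25000 nM, with an expected range of 12000 nM to 50000 nM.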

Compound 4, half-maximal cytotoxic concentration: > 20000 nM
Compound 4: no number, only a limit; the forecaster's own chance of this, stated with the estimate: 85%; the middle value does not contradict the limit.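

Compound 3 and compound 4 both give only a limit and not a number, so the step from 3-methoxyphenyl to 4-ethylphenyl cannot be read: the limit of > 20000 nM in this assay, at which 4 of the 4 values shown sit.

The compounds shown leave open at what concentration any of them would reduce cell survival in this assay, and whether these benzyl groups differ in that respect.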